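Swapping the 4-Chlorophenyl for a Pyridin-3-yl Ring

This account rests on a few compounds, and the source may have more. Where it says the series, first, only, none or still open, it means among the compounds named here.

Three compounds share one core and differ only in the group on a carbonyl carbon. In an assay on isolated protein for inhibition of aldehyde dehydrogenase 1A1 (Homo sapiens), read by spectrophotometry, tested at 10 uM (a higher number here means more inhibition at the concentration tested (going by the name of the read-out), a lower number less inhibition), compound 1 `COc1ccc(C(=O)N2CCN(Cc3nc4ccccc4n3Cc3cccc(C)c3)CC2)cc1` gives 55.5%, compound 2 `Cc1cccc(Cn2c(CN3CCN(C(=O)c4ccc(C(C)C)cc4)CC3)nc3ccccc32)c1` gives 67.6%, and compound 3 `Cc1cccc(Cn2c(CN3CCN(C(=O)c4ccc(Cl)cc4)CC3)nc3ccccc32)c1` gives 23.2%, the lowest of the three. The steps of a number 32.3 percentage points lower from compound 1 to compound 3 (beyond the scatter) and a number 44.4 percentage points lower from compound 2 to compound 3 (beyond the scatter) show that the number for the 4-chlorophenyl group is the lowest of the three substituent patterns measured. Compound 4 `Cc1cccc(Cn2c(CN3CCN(C(=O)c4cccnc4)CC3)nc3ccccc32)c1` replaces that whole group: pyridin-3-yl in place of 4-chlorophenyl on a carbonyl carbon. Going by the values given here, no measured step exchanges the entire ring, so these steps bear on it only loosely; they show that compound 3 sits low and leaves room to move upward. A modest rise is therefore expected, a number 16.8 percentage points higher from compound 3 to compound 4 (beyond the scatter). Compound 4 is estimated at 40%, within 15% to 65%.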

Compound 4, a percentage reported as inhibition, at one concentration (the size of the read-out at that concentration, not a potency): 24.5%
Estimate against measurement, compound 4: 15.5 percentage points above, and the stated range covers the measured number.
By their numbers in this assay, from the lowest: compounds 3 and 4 (each within the scatter of the next); then compound 1; then compound 2.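

Exchanging the whole ring leaves the number in this assay essentially unchanged (a number 1.3 percentage points higher from compound 3 to compound 4 (within the scatter)), so on this carbonyl carbon pyridin-3-yl and 4-chlorophenyl cannot be told apart. Pyridin-3-yl also falls well short of 4-isopropylphenyl (a number 43.1 percentage points lower from compound 2 to compound 4 (beyond the scatter)) and of 4-methoxyphenyl (a number 31 percentage points lower from compound 1 to compound 4 (beyond the scatter)). Thus a ring nitrogen, with its hydrogen-bond acceptor, brings no measurable gain over 4-chlorophenyl, and nothing available explains why these two rings read alike.

Still open, as far as these compounds go, is whether pyridin-4-yl would read like pyridin-3-yl. Also open, from the compounds shown here alone, is whether 4-tert-butylphenyl would match or exceed 4-isopropylphenyl.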